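The source may report more compounds than this note shows. Statements on the series, on what has been measured and on what is new or still open speak of the compounds shown alone.

Of the compounds shown here, two have numbers so far. In a functional assay on HeLa cells (Homo sapiens) for antiproliferative activity, read by MTT assay, with a stated time of 72 h (a lower number here means a stronger inhibitor, a higher number a weaker inhibitor), compound 2 `C=CC(=O)Nc1cccc(Oc2nc(Nc3ccc(OC)cc3)nc3c2CSCC3)c1` gives 20900 nM, and compound 1 `CC/C=C/C(=O)Nc1cccc(Oc2nc(Nc3cccc(OC)c3)nc3c2CSCC3)c1` gives 27200 nM. Within the data shown here, these two numbers lie within the scatter of each other, so compound 2 cannot be separated from the only other measured compound.

Compound 3 `CC/C=C/C(=O)Nc1cccc(Oc2nc(Nc3ccc(OC)cc3)nc3c2CSCC3)c1` is the next to be read. It follows from compound 2 by one change, but-1-en-1-yl in place of vinyl on a carbonyl carbon.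

Among the measured compounds shown here, no measured pair differs in one place only, so this change has no direct precedent. Compound 1 also carries but-1-en-1-yl on a carbonyl carbon, and its number of 27200 nM lies within the scatter of the number for compound 2. On this thin evidence, no step beyond the scatter is expected in this assay, in either direction. The expected change is a 1.1-fold higher number from compound 2 to compound 3 (0.06 log units; within the scatter). For compound 3 the estimate is 24000 nM, with an expected range of 11000 nM to 50000 nM.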

Compound 3, half-maximal inhibitory concentration: 27200 nM
For compound 3 the middle estimate is 1.1-fold (0.05 log units) below the measured one; the measured number falls inside the stated range.
By their numbers in this assay, from the lowest: compounds 2, 1 and 3 (each within the scatter of the next).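

In this assay, among these compounds, but-1-en-1-yl in place of vinyl on a carbonyl carbon whose other neighbour is an amide-type nitrogen gives a 1.3-fold higher number from compound 2 to compound 3 (0.11 log units; within the scatter) and so supplies the first direct one-place reading at this position, where the two groups cannot be separated. The methoxy group gets its first one-place reading too: 4-methoxyphenyl in place of 3-methoxyphenyl on a nitrogen on an aromatic ring gives no change at the digits printed from compound 1 to compound 3 (within the scatter) and leaves the two compounds equally inseparable, so neither change has yet been seen to move the number beyond the scatter. No independent measurement is at hand that bears on either step.

The compounds shown cover only but-1-en-1-yl and vinyl on the carbonyl carbon and only two placements of the methoxy group, so it remains open whether either position can shift the number at all. A dimethylamino group at the end of the but-1-en-1-yl chain, a saturated propyl chain on the carbonyl carbon, or a carboxylic acid in place of the methoxy group would test this.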